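The source may report more compounds than this note shows. Statements on the series, on what has been measured and on what is new or still open speak of the compounds shown alone.

Compound 1 `CN(C(=O)NC(=O)c1ccccc1F)c1nc(C(F)(F)F)c(C(=O)N/N=C/c2ccccc2C(F)(F)F)s1` gives 5.39 ug/mL.
Compound 2 `CNc1nc(C(F)(F)F)c(C(=O)N/N=C/c2ccccc2C(F)(F)F)s1` gives only a limit of the assay, > 100 ug/mL.
Compound 3 `CN(C(=O)NC(=O)c1ccccc1F)c1nc(C(F)(F)F)c(C(=O)N/N=C/c2cccc(C(F)(F)F)c2)s1` gives 20.3 ug/mL.

In a functional assay on HepG2 cells (Homo sapiens) for inhibition, read by MTT assay, with a stated time of 72 h (a higher number here means a weaker inhibitor, a lower number a stronger inhibitor), compound 1 holds the lowest of the two numbers, with compound 3 showing a 3.8-fold higher number from compound 1 to compound 3 (0.58 log units; beyond the scatter). Compound 2 sits at a limit, not a number, as the limit of > 100 ug/mL in this assay, at which 1 of the 3 values shown sits, states. Compound 4 `CN(C(=O)NC(=O)c1c(Cl)cccc1Cl)c1nc(C(F)(F)F)c(C(=O)N/N=C/c2ccccc2C(F)(F)F)s1` differs from compound 1 in one place: 2,6-dichlorophenyl in place of 2-fluorophenyl on a carbonyl carbon. Going by the values given here, no measured step alters this ring directly. The step of an at least 18-fold higher number from compound 1 to compound 2 (1.26 log units; beyond the scatter) shows that removing the whole ((2-fluorophenyl)carbonyl)carbamoyl group matters greatly, while compound 4 keeps it. Compound 4 is therefore expected to change little, a 1.1-fold higher number from compound 1 to compound 4 (0.05 log units; within the scatter), within the scatter. The estimated value for compound 4 is 6 ug/mL, with a range from 2.5 ug/mL to 15 ug/mL.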

Compound 4, half-maximal inhibitory concentration: 8.95 ug/mL
Compound 4: middle estimate off by 1.5-fold (0.17 log units), on the low side; the range from low to high includes it.
By their numbers in this assay, from the lowest: compounds 1 and 4 (each within the scatter of the next); then compound 3. At a limit, above all of these: compound 2.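

Swapping 2-fluorophenyl for 2,6-dichlorophenyl on the carbonyl carbon keeps the reading in this assay within the usual variation between repeats: a 1.7-fold higher number from compound 1 to compound 4 (0.22 log units; within the scatter). Going by these compounds alone, this position therefore accepts two chlorines in place of one fluorine without a measurable change, something the earlier compounds could not show, as they either carried 2-fluorophenyl or lacked the whole group. Nothing measured here explains this tolerance. Still open, as far as these compounds go, is how far the tolerance extends. An unsubstituted phenyl, a methoxyphenyl, a pyridine ring or a non-aromatic cyclohexyl group might give a different result.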